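A few compounds are considered here, and "the series" means these few. Any claim that something is new, unique, unknown or untested is made for them only; others in the source may bear on it.

Measured compounds:
compound 1 `CSc1cnc2ccccc2c1SCC#CCOC(=O)/C=C/c1ccccc1`: 66.6 ug/mL
compound 2 `CCOC(=O)OCC#CCSc1c(SC)cnc2ccccc12`: 33.1 ug/mL
compound 3 `CSc1cnc2ccccc2c1SCC#CCO`: 34.9 ug/mL

All three numbers come from a functional assay on SW707 cells (Homo sapiens) for antiproliferative activity, with a stated time of 72 h; on this read-out higher numbers stand for weaker inhibition and lower numbers for stronger inhibition. Within the data shown here, compound 2 stands at the lowest of the three numbers, but the whole set is tight: the step of a 1.1-fold higher number from compound 2 to compound 3 (0.02 log units; within the scatter) and the step of a 2.0-fold lower number from compound 1 to compound 2 (0.30 log units; within the scatter) both stay within the scatter, so no compound is separated from another on this read-out.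

The next compound is compound 4 `CSc1cnc2ccccc2c1SCC#CCOC(=O)c1ccc(C(=O)O)cc1`. It keeps the core and the alkyne-linked chain of compound 2 and differs only at the ester end: 4-carboxyphenyl in place of ethoxy on a carbonyl carbon.

Among the measured compounds shown here, two measured steps touch this part of the molecule. The step of a 2.0-fold lower number from compound 1 to compound 2 (0.30 log units; within the scatter) changes the same carbonyl carbon, exchanging one substituent for another, and stays within the scatter. The step of a 1.1-fold higher number from compound 2 to compound 3 (0.02 log units; within the scatter) removes the ethoxycarbonyl altogether and also stays within the scatter. For the measured compounds named here, nothing measured here suggests that what sits on this carbonyl carbon moves the number beyond the scatter, and no compound with a carboxylic acid has been measured.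

The step to compound 4 is therefore expected to be a 1.2-fold higher number from compound 2 to compound 4 (0.08 log units; within the scatter), within the scatter. Compound 4 is estimated at 40 ug/mL, with a range from 15 ug/mL to 110 ug/mL.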

Compound 4, concentration for 50% inhibition: 28.1 ug/mL
Beside the measured number, compound 4's estimate is 1.4-fold (0.15 log units) above it, and the stated range covers the measured number.
By their numbers in this assay, from the lowest: compounds 4, 2, 3 and 1 (each within the scatter of the next, the first and the last beyond it).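

In this assay, the carbonyl carbon takes 4-carboxyphenyl, with its six-membered aromatic ring and hydrogen-bond donor, in place of the much smaller ethoxy without the number separating: a 1.2-fold lower number from compound 2 to compound 4 (0.07 log units; within the scatter). The same position now gives the first separation in the series, though a modest one, as exchanging 2-phenylethenyl for 4-carboxyphenyl gives a 2.4-fold lower number from compound 1 to compound 4 (0.37 log units; beyond the scatter), while compound 2, with ethoxy, stays within the scatter of both compound 1 and compound 4, so the position tolerates groups of quite different size and only its two aromatic-bearing substituents are told apart. No available evidence bears on what lies behind these numbers.

From the compounds shown here alone, whether the carboxylic acid itself matters stays open, since compound 4 changes the ring-bearing substituent as a whole and an amine or a methyl ester at that end of the 4-carboxyphenyl group would be needed to isolate it. Going by these compounds, it is also open whether a longer alkyl chain in place of ethoxy on the carbonyl carbon would stay within the scatter of compound 2 in this assay or move apart from it.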